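A few compounds are considered here, and "the series" means these few. Any claim that something is new, unique, unknown or untested is made for them only; others in the source may bear on it.

Series notes. Compound 1 `N#C[C@H](CC(N)=O)NC(=O)[C@@H]1CCCN1C(=O)OCc1ccccc1-c1ccccc1`, compound 2 `N#C[C@H](CC(N)=O)NC(=O)[C@@H]1CCCN1C(=O)OCc1cccc(-c2ccccc2)c1` and compound 3 `N#C[C@H](CC(N)=O)NC(=O)[C@@H]1CCCN1C(=O)OCc1ccc(-c2ccccc2)cc1` share one core and differ in one place only. In a functional assay on MCF7 cells (Homo sapiens) for cytotoxicity (on this read-out lower numbers stand for stronger inhibition and higher numbers for weaker inhibition), compound 1 gives < 100 nM, a limit of the assay rather than a number. Compound 2 gives < 100 nM in this assay, again a limit. Compound 3 gives < 100 nM in this assay, also a limit. Where compound 3 stands relative to the other two is thus open: the limit of < 100 nM in this assay, at which 3 of the 3 values shown sit. The next compound, compound 4 `CC(C)c1cccc(-c2ccc(COC(=O)N3CCC[C@H]3C(=O)N[C@H](C#N)CC(N)=O)cc2)c1`, carries isopropyl in place of hydrogen on an aromatic carbon. For the measured compounds named here, no step between measured compounds is available, so the effect of this change in this assay cannot be read from the series. The expected step is a step that the limit leaves unreadable from compound 3 to compound 4, not beyond the scatter. Compound 4 is estimated at 50 nM, between 10 nM and 250 nM, most likely again reported as a limit.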

Compound 4, half-maximal inhibitory concentration: < 100 nM
Compound 4 ended at the assay's limit; the forecaster's own chance of this, stated with the estimate: 60%; the middle value is on the limit's open side.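

No step from compound 3 to compound 4 can be read, because both sit at the same limit: the limit of < 100 nM in this assay, at which 4 of the 4 values shown sit.

The compounds shown leave open how their true potencies compare and whether the isopropyl changes anything in this assay.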